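Quinone and hydroquinone pyrazoles: cytotoxicity notes

A few compounds are considered here, and "the series" means these few. Any claim that something is new, unique, unknown or untested is made for them only; others in the source may bear on it.

Measured so far:
- compound 1, `NS(=O)(=O)c1ccc(-n2nc(-c3ccc(Cl)cc3)cc2-c2cc(O)ccc2O)cc1`: 29800 nM
- compound 2, `O=C1C=CC(=O)C(c2cc(-c3ccc(Cl)cc3)nn2-c2ccccc2)=C1`: 66400 nM
- compound 3, `Cc1ccc(-c2cc(C3=CC(=O)C=CC3=O)n(-c3ccc(S(N)(=O)=O)cc3)n2)cc1`: 100000 nM

In a functional assay on cells (Cancer cell lines, Homo sapiens) for cytotoxicity, read by sulforhodamine B assay, with a stated time of 48 h (on this read-out higher numbers stand for weaker inhibition of growth and lower numbers for stronger inhibition of growth), compound 1 gives 29800 nM, compound 2 gives 66400 nM and compound 3 gives 100000 nM. Compound 3 has the highest number of the three. Against compound 2 the gap falls within the usual scatter, so no order between compound 2 and compound 3 can be read from these two values; against compound 1 the gap is beyond the scatter, and compound 1 stands at the lower number.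

Compound 4, `NS(=O)(=O)c1ccc(-n2nc(-c3ccc(Cl)cc3)cc2C2=CC(=O)C=CC2=O)cc1`, is not yet measured. Relative to compound 3 the change is chloro in place of methyl on an aromatic carbon, para to a large group. Among the measured compounds shown here, no measured pair shows this single exchange, so no step is known for it. The change is small, and compound 2, which carries the same 4-chlorophenyl, sits within the scatter of compound 3 in this assay. The step from compound 3 to compound 4 is therefore expected to be modest, a 1.5-fold lower number from compound 3 to compound 4 (0.19 log units; within the scatter), toward a somewhat lower number but not clearly beyond the scatter. Compound 4 is estimated at 65000 nM, with a range from 28000 nM to 100000 nM.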

Compound 4, concentration for total growth inhibition: 71900 nM
Beside the measured number, compound 4's estimate is 1.1-fold (0.04 log units) below it, and the stated range covers the measured number.
By their numbers in this assay, from the lowest: compound 1; then compounds 2, 4 and 3 (each within the scatter of the next).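

In this assay the exchange of methyl for chloro on an aromatic carbon, para to a large group, gives a 1.4-fold lower number from compound 3 to compound 4 (0.14 log units; within the scatter) and so separates 4-methylphenyl from 4-chlorophenyl by no readable amount in this series, while sulfamoyl in place of hydrogen on an aromatic carbon gives a 1.1-fold higher number from compound 2 to compound 4 (0.03 log units; within the scatter) and likewise leaves no readable gap. Among the compounds shown here, the one exchange beyond the scatter is the six-membered non-aromatic ring group in place of the six-membered aromatic ring group, which gives a 2.4-fold higher number from compound 1 to compound 4 (0.38 log units; beyond the scatter) as a modest step. Nothing available here accounts for any of these steps.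

Open, on these data alone, is how an amine or a carboxylic acid on that aromatic carbon would read in this assay against chloro and methyl. Also open is whether the step between the two ring groups holds with 4-methylphenyl in place of 4-chlorophenyl, as only one such pair is shown.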